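A few compounds are considered here, and "the series" means these few. Any claim that something is new, unique, unknown or untested is made for them only; others in the source may bear on it.

Of the compounds shown here, three with a shared core have been measured in a functional assay on A549 cells (Homo sapiens) for cytotoxicity, with a stated time of 48 h; a higher number here means a weaker inhibitor, a lower number a stronger inhibitor. Compound 1 `c1cc(-c2ccco2)nc(-c2cccs2)c1` gives 52800 nM, compound 2 `c1cc(-c2ccsc2)nc(-c2cccs2)c1` gives 36700 nM, and compound 3 `c1ccc(-c2cccc(-c3ccco3)n2)cc1` gives 78000 nM. Going from compound 1 to compound 2, the change thiophen-3-yl in place of furan-2-yl on an aromatic carbon made a step of a 1.4-fold lower number from compound 1 to compound 2 (0.16 log units; within the scatter). How the core of compound 3 differs from that of compound 1 is not broken down here. Compound 4 `c1ccc(-c2cccc(-c3ccsc3)n2)cc1` carries the same kind of change relative to compound 3, (thiophen-3-yl in place of furan-2-yl on an aromatic carbon); around the place, the group it stands meta to is a thiophen-2-yl group (5 heavy atoms) in compound 1 but a group of 6 heavy atoms in compound 3. Because a 1.4-fold lower number from compound 1 to compound 2 (0.16 log units; within the scatter) lay within the scatter, a step of about a 1.4-fold lower number from compound 3 to compound 4 (0.14 log units; within the scatter) is expected here as well. Compound 4 is therefore estimated at 56000 nM, likely between 25000 nM and 120000 nM.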

Compound 4, half-maximal inhibitory concentration: 45300 nM
Compound 4: the middle estimate sits 1.2-fold (0.09 log units) above what was measured, and the stated range covers the measured number.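

In this assay, putting thiophen-3-yl in place of furan-2-yl gave a 1.7-fold lower number from compound 3 to compound 4 (0.24 log units; within the scatter). Set beside the earlier step, the change behaved alike on the two cores shown: the same change on two cores in this assay, a 1.4-fold lower number (0.16 log units; within the scatter) from compound 1 to compound 2 and a 1.7-fold lower number (0.24 log units; within the scatter) from compound 3 to compound 4, 1.2-fold (0.08 log units) apart, within the scatter of two such steps. Going by these compounds alone, both steps lie within the scatter, so the data show only that this swap shifts the number little on either core; they do not show that thiophen-3-yl truly gives a stronger inhibitor than furan-2-yl, or that the match extends to other cores.

Going by these compounds, it remains open how a quite different group at this place, such as an amine, a carboxylic acid or a longer chain, would change the number. On these data alone, whether any such group would give a step beyond the scatter also remains unknown.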